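Exchanging the amine-bearing group on an aromatic nitrogen

A few compounds are considered here, and "the series" means these few. Any claim that something is new, unique, unknown or untested is made for them only; others in the source may bear on it.

Compound 2 `C=CC(=O)Nc1cccc(-n2c(-c3nc(-c4cnn(CCN5CCN(C)CC5)c4)cnc3N)nc3ccccc32)c1` carries a 2-(4-methylpiperazin-1-yl)ethyl group on an aromatic nitrogen of a five-membered aromatic ring with 2 nitrogen. Among the measured compounds shown here, in a physicochemical assay for solubility, at pH 7.4 (on this read-out lower numbers stand for lower solubility and higher numbers for higher solubility), compound 2 gives 30000 nM, the only actual number among the two values shown. Compound 1 `C=CC(=O)Nc1cccc(-n2c(-c3nc(-c4cnn(C)c4)cnc3N)nc3ccccc32)c1` differs from compound 2 only by a hydrogen in place of the (4-methylpiperazin-1-yl)methyl on the saturated chain carbon bound to that aromatic nitrogen. In this assay compound 1 gives < 10000 nM, which is a limit of the assay rather than a number. For the measured compounds named here, the single measured step, an at least 3.0-fold higher number from compound 1 to compound 2 (0.47 log units; beyond the scatter), is therefore known only as a bound, since one value sits at the limit of < 10000 nM in this assay, at which 1 of the 2 values shown sits.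

Compound 3 `C=CC(=O)Nc1cccc(-n2c(-c3nc(-c4cnn(C5CCN(C(C)C)CC5)c4)cnc3N)nc3ccccc32)c1` introduces (1-isopropylpiperidin-4-yl in place of 2-(4-methylpiperazin-1-yl)ethyl on an aromatic nitrogen). The measured step concerns adding a whole group to a hydrogen-bearing carbon, whereas this change trades one group for another of similar make-up, so it bears only loosely here. The exchange is expected to stay within the scatter: a 1.2-fold lower number from compound 2 to compound 3 (0.08 log units; within the scatter). Compound 3 is thus estimated at 25000 nM, expected to lie between 8000 nM and 80000 nM.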

Compound 3, solubility: < 10000 nM
Compound 3: a limit, no number; the forecaster's own chance of this, stated with the estimate: 15%; at least 2.5-fold (0.39 log units) between middle value and limit.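

At this aromatic nitrogen, not every amine-bearing group holds the reading of compound 2: in this assay, placing 1-isopropylpiperidin-4-yl where 2-(4-methylpiperazin-1-yl)ethyl stood gives an at least 3.0-fold lower number from compound 2 to compound 3 (0.47 log units; beyond the scatter). The value of compound 3 is a limit of the assay, so this step is known only as a bound, and compound 3 joins compound 1 at that limit: the limit of < 10000 nM in this assay, at which 2 of the 3 values shown sit. The step from compound 1 to compound 3 cannot be read, as both values are limits.

The exchange alters the ring and its link to the aromatic nitrogen together, so the compounds shown leave open which of the two changes accounts for the step. On these data alone, a 2-(piperidin-1-yl)ethyl group on the same nitrogen would separate them, and how far compound 3 lies beyond the limit also remains unknown.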